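This account rests on a few compounds, and the source may have more. Where it says the series, first, only, none or still open, it means among the compounds named here.

Measured compounds and their values:
Compound 1, `CCCCCCCCCCCOc1ccccc1CCC(=O)OC[C@H]1OCCC[C@H]1OP(=O)(O)OC[C@H](N)C(=O)O`: 0.41
Compound 2, `N[C@@H](COP(=O)(O)OC[C@H]1OCC=C[C@H]1OC(=O)CCc1ccccc1OCc1cccc(Oc2ccccc2)c1)C(=O)O`: 0.86
Compound 3, `N[C@@H](COP(=O)(O)OC[C@H]1OCCC[C@@H]1OC(=O)CCc1ccccc1OCc1cccc(Oc2ccccc2)c1)C(=O)O`: "not active" (no number reported)

In an assay on HEK293-A cells with probable G-protein coupled receptor 34 (Mus musculus) as the target, with a stated time of 1.5 h (a lower number here means a smaller maximal response, a higher number a larger maximal response), compound 1 gives 0.41. This is the lowest of the two numbers reported; compound 2 gives 0.86, which lies above compound 1 by more than the scatter. Compound 3 was reported as not active in this assay, with no number attached.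

The compound under consideration is compound 4, `CCCCCCCCCCCOc1ccccc1CCC(=O)OC[C@H]1OCCC[C@@H]1OP(=O)(O)OC[C@H](N)C(=O)O`. It is related to compound 1 as follows: the two compounds have the same atoms and bonds; at least one stereo element is drawn with a configuration in one of them and without one in the other: 1 of 4 stereo elements differ; a stereocentre at a saturated ring carbon is drawn R in compound 1 and S in compound 4. Nothing leaves and nothing enters; the only difference is the drawn configuration at that saturated ring carbon.

For the measured compounds named here, no step between measured compounds that differ in a single place is available, so the size of the change has to be judged from the compounds as they stand. Compound 3 carries the same configuration at the saturated ring carbon as compound 4 and is reported as not active, while compounds 1 and 2 carry the other configuration and give numbers. Because of "not active" (no number reported) for compound 3, compound 4 is expected to fall below compound 1 by more than the scatter, with a fair chance of being reported as not active. Compound 4 is thus estimated at 0.15 (range 0 to 0.4), an expected step of a number 0.26 lower from compound 1 to compound 4 (beyond the scatter).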

Compound 4, intrinsic activity: the largest response reached, as a fraction of the reference agonist's: 0.082
For compound 4 the middle estimate is 0.068 above the measured one, and the stated range covers the measured number.
By their numbers in this assay, from the lowest: compound 4; then compound 1; then compound 2.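

In this assay, redrawing the saturated ring carbon from R to S, with nothing leaving and nothing entering, gives a large step: a number 0.33 lower from compound 1 to compound 4 (beyond the scatter). For the compounds shown here, this pair is the first in the set to isolate this single position, and it shows that the configuration there can by itself govern how large a maximal response the compound reaches, while compound 4 still gives a number, 0.082, rather than a report of not active. The step can be tied to this one place, because nothing else separates the two compounds: the fact that one of compounds 1 and 4 is drawn with a defined configuration and the other without, at the place where they differ

The compounds shown leave open whether the same inversion costs a similar amount on a different side chain, as no other pair differs only at this carbon, and whether the other stereocentres of the core matter to the same degree. They also do not tell how the response at either configuration would change if the chain of compound 1 were replaced by a longer chain, or if the ester were replaced by an amide.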